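Trimming the Ester Tail of Compound 2

A few compounds are considered here, and "the series" means these few. Any claim that something is new, unique, unknown or untested is made for them only; others in the source may bear on it.

Compound 1 `CCCCN(CCCC)Cc1cn(CC(O)COC(=O)C2CCCCC2)nn1` and compound 2 `CCCCN(CCCC)Cc1cn(CC(O)COC(=O)c2ccccc2)nn1` share one core and differ only in the group on the carbonyl carbon. In an assay on nucleic acid for inhibition of Nucleic Acid, read by fluorescence, tested at 100 uM (a higher number here means more inhibition at the concentration tested (going by the name of the read-out), a lower number less inhibition), compound 1 gives 12%, and compound 2 gives 12%; no change at the digits printed from compound 1 to compound 2 (within the scatter). Compound 2 therefore stands level with compound 1, both at a low level of inhibition at the concentration tested. Compound 3 `CCCCC(O)Cn1cc(CN(CCCC)CCCC)nn1` is not yet measured and differs from compound 2 by propyl in place of benzoyloxy on a saturated chain carbon, two bonds along the chain from an oxygen on a saturated carbon. Going by the values given here, no measured step covers this change: the only step, from compound 1 to compound 2, alters the ring on the carbonyl carbon and is flat within the scatter, which says nothing about removing the whole ester. Because compound 2 gives 12% at a low level, the expected step is no change at the digits printed from compound 2 to compound 3 (within the scatter), essentially none beyond the scatter. Compound 3 is estimated at 12%, within a range from 0% to 25%.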

Compound 3, a percentage reported as inhibition, at one concentration (the size of the read-out at that concentration, not a potency): 18%
The estimate for compound 3 lay 6 percentage points below the measured number; the range from low to high includes it.
By their numbers in this assay, from the lowest: compounds 1, 2 and 3 (each within the scatter of the next).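

In this assay, propyl in place of benzoyloxy on a saturated chain carbon, two bonds along the chain from an oxygen on a saturated carbon, gives a number 6 percentage points higher from compound 2 to compound 3 (within the scatter), and propyl in place of (cyclohexylcarbonyl)oxy at the same place gives a number 6 percentage points higher from compound 1 to compound 3 (within the scatter). The earlier step exchanged only the ring on the carbonyl carbon, whereas these two show that the entire ester, ring and carbonyl included, can give way to a plain propyl without a step beyond the scatter. Nothing available explains why the read-out stays within the scatter across this change.

From the compounds shown here alone, all three compounds sit at a low level of inhibition, so it remains open whether any group at this place can lift the read-out beyond the scatter. An amine, a carboxylic acid or a chain longer than propyl at this carbon would each put that question to the test.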